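Swapping the phenol ring on a hydrazone series

The source may hold more compounds than are shown below. What is called first, only, known or untested is meant among the compounds shown, and "the series" means these compounds.

Measured compounds:
compound 1 `Cc1c(C(=O)N/N=C\c2ccc(O)cc2)oc2cccc(O)c12` — 21700 nM
compound 2 `Cc1c(C(=O)N/N=C\c2cccc(O)c2O)oc2cccc(O)c12` — 12200 nM

Among the measured compounds shown here, compound 2 `Cc1c(C(=O)N/N=C\c2cccc(O)c2O)oc2cccc(O)c12` holds the lowest number of the two measured in a functional assay on PC-3 cells (Homo sapiens) for inhibition (on this read-out lower numbers stand for stronger inhibition and higher numbers for weaker inhibition), with compound 1 `Cc1c(C(=O)N/N=C\c2ccc(O)cc2)oc2cccc(O)c12` as its only neighbour; the step of a 1.8-fold lower number from compound 1 to compound 2 (0.25 log units; within the scatter) lies within the scatter, so the two cannot be ranked against each other.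

Compound 3 `Cc1c(C(=O)N/N=C\c2c(O)cccc2Cl)oc2cccc(O)c12` differs from compound 2 in one place: 2-chloro-6-hydroxyphenyl in place of 2,3-dihydroxyphenyl on a carbon with a double bond to nitrogen. For the measured compounds named here, only one measured step touches the same position, that from compound 1 to compound 2, and it was small, a 1.8-fold lower number from compound 1 to compound 2 (0.25 log units; within the scatter). Going by the values given here, it exchanged one hydroxyphenyl pattern for another; the present change instead brings in a chlorine beside a single hydroxyl, for which no measured pair gives guidance. Without a step beyond the scatter on record, no shift beyond the scatter is expected in this assay either direction.

Compound 3 is therefore estimated at 13000 nM, with a range of 4500 nM to 40000 nM, a step of a 1.1-fold higher number from compound 2 to compound 3 (0.03 log units; within the scatter) that is expected to stay within the scatter.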

Compound 3, half-maximal inhibitory concentration: 18700 nM
Estimate against measurement, compound 3: 1.4-fold (0.16 log units) below; low and high end bracket the measured number.
By their numbers in this assay, from the lowest: compounds 2, 3 and 1 (each within the scatter of the next).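

In this assay, 2-chloro-6-hydroxyphenyl in place of 2,3-dihydroxyphenyl gives a 1.5-fold higher number from compound 2 to compound 3 (0.19 log units; within the scatter), and the same group in place of 4-hydroxyphenyl gives a 1.2-fold lower number from compound 1 to compound 3 (0.06 log units; within the scatter). The place on a carbon with a double bond to nitrogen has thus now taken a ring carrying a chlorine, with 1 hydrogen-bond donor and 1 hydrogen-bond acceptor where 2,3-dihydroxyphenyl has 2 of each, and neither step leaves the scatter, so the three compounds cannot be ranked against one another. No independent measurement is available that could account for how these numbers relate.

Going by these compounds, whether a ring at this place carrying an amine or a carboxylic acid, or a plain phenyl with no hydroxyl at all, would give a step beyond the scatter stays open. On these data alone, the shared core is the same in all three compounds, so what a change there would do in this assay stays open as well.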